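The source may report more compounds than this note shows. Statements on the series, on what has been measured and on what is new or still open speak of the compounds shown alone.

Measured compounds in a functional assay on SW480 cells (Homo sapiens) for cytotoxicity, read by MTT assay, with a stated time of 48 h; on this read-out higher numbers stand for weaker inhibition and lower numbers for stronger inhibition:
compound 1 `N#Cc1ccc(Cn2cc(COc3ccc4c(=O)ccoc4c3)nn2)cc1` gives > 100000 nM, which is a limit of the assay.
compound 2 `O=c1ccoc2cc(OCc3cn(Cc4ccccc4Br)nn3)ccc12` gives > 100000 nM, also a limit.
compound 3 `Cc1ccccc1Cn1cc(COc2ccc3c(=O)ccoc3c2)nn1` gives > 100000 nM, again a limit.

Every value shown sits at the limit of > 100000 nM in this assay, at which 3 of the 3 values shown sit, so compound 3 stands at the limit and nowhere else on the numbers shown. Compound 4 `O=c1ccoc2cc(OCc3cn(Cc4ccccc4Cl)nn3)ccc12` differs from compound 3 by chloro in place of methyl on an aromatic carbon. The step most nearly related to this change is a step that the two limits leave unreadable from compound 2 to compound 3, taken in reverse; the steps a step that the two limits leave unreadable from compound 1 to compound 2 and a step that the two limits leave unreadable from compound 1 to compound 3 are equally unreadable. Among the compounds with values here, no measured step carries a size, so no step beyond the scatter is expected in this assay, and compound 4 is expected to return a limit as well. For compound 4 the estimate is 150000 nM, with a range from 50000 nM to 500000 nM, meaning an expected step that the limit leaves unreadable from compound 3 to compound 4.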

Compound 4, half-maximal inhibitory concentration: 23500 nM
Beside the measured number, compound 4's estimate is 6.4-fold (0.81 log units) above it, outside the stated range (below it).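

In this assay, within the data shown here, chloro on the benzyl ring gives the first readable steps in this set: an at least 4.2-fold lower number from compound 3 to compound 4 (0.62 log units; beyond the scatter), an at least 4.2-fold lower number from compound 2 to compound 4 (0.62 log units; beyond the scatter) and an at least 4.2-fold lower number from compound 1 to compound 4 (0.62 log units; beyond the scatter). Chloro therefore separates from both methyl and bromo at the same place, so the response does not simply follow from having a group there. These sizes are only lower bounds, and the steps among compound 1, compound 2 and compound 3 cannot be read: the limit of > 100000 nM in this assay, at which 3 of the 4 values shown sit.

Going by these compounds, whether fluoro, methoxy or an amine at this place would give a lower number remains open. So does whether chloro elsewhere on the ring would keep the step.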